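The source may report more compounds than this note shows. Statements on the series, on what has been measured and on what is new or still open speak of the compounds shown alone.

Compound 1 `CCOC(=O)c1ccc(-c2nn(C)c3ccccc23)cc1`: in a functional assay on cells (Platelet, Homo sapiens) for inhibition (a higher number here means a weaker inhibitor, a lower number a stronger inhibitor), compound 1 gives > 10000 nM, a limit of the assay.
Compound 2 `CCOC(=O)c1ccc(-c2nn(Cc3ccccc3F)c3ccccc23)cc1`: in this assay compound 2 gives > 10000 nM, a limit.
Compound 3 `CCOC(=O)c1ccc(-c2nn(Cc3cccc(F)c3)c3ccccc23)cc1`: in this assay compound 3 gives > 10000 nM, a limit.

Compound 3 therefore stands only at a limit, as do the two other compounds; all three sit at the limit of > 10000 nM in this assay, at which 3 of the 3 values shown sit. Compound 4 `CCOC(=O)c1ccc(-c2nn(Cc3ccccc3OC)c3ccccc23)cc1` differs from compound 3 by 2-methoxyphenyl in place of 3-fluorophenyl on a saturated chain carbon bound to an aromatic nitrogen. Going by the values given here, the steps that bear on this change are a step that the two limits leave unreadable from compound 1 to compound 3 and a step that the two limits leave unreadable from compound 2 to compound 3, both unreadable; a step that the two limits leave unreadable from compound 1 to compound 2 is likewise unreadable. Every value involved is a limit. Among the compounds with values here, no measured step gives a readable size, so the expectation for compound 4 in this assay is a step that the limit leaves unreadable from compound 3 to compound 4, with the reported value most likely again a limit. Compound 4 is estimated at 15000 nM, within 5000 nM to 50000 nM.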

Compound 4, half-maximal inhibitory concentration: > 10000 nM
Compound 4 was reported as a limit (the forecaster's own chance of this, stated with the estimate: 85%); the middle value is on the limit's open side.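

No step to compound 4 from compound 1, compound 2 or compound 3 can be read, as all four compounds stand at a single limit: the limit of > 10000 nM in this assay, at which 4 of the 4 values shown sit.

The compounds shown leave open how strongly any of them inhibits in this assay, and whether 2-methoxybenzyl and 3-fluorobenzyl differ there at all.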